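From an Aryl Carbamoyl to a Trifluoromethyl Group

The compounds below may be only part of what the source reports. "The series", "measured", "known", "first", "only" and "open" are said of these compounds alone.

Compound 1, `O=C(CCCCCc1ccc(O)cc1)N1CCOC1=O`, gives 61 nM in an assay on HEK293 cells for inhibition of N-acylethanolamine-hydrolyzing acid amidase (Rattus norvegicus), read by LC-MS, with a stated time of 30 min; a higher number here means a weaker inhibitor, a lower number a stronger inhibitor.
Compound 2, `O=C(O)c1ccc(CCCCCC(=O)N2CCOC2=O)cc1`, reaches only the limit > 20000 nM in this assay.
Compound 3, `NC(=O)c1ccc(CCCCCC(=O)N2CCOC2=O)cc1`, likewise reaches only the limit > 20000 nM in this assay.

Compound 3 therefore stands at the limit of > 20000 nM in this assay, at which 2 of the 3 values shown sit, and no number is attached to it. The steps that lead there are large: an at least 320-fold higher number from compound 1 to compound 2 (2.51 log units; beyond the scatter) and an at least 320-fold higher number from compound 1 to compound 3 (2.51 log units; beyond the scatter). Between the two limits, a step that the two limits leave unreadable from compound 2 to compound 3, so the comparison of carboxy and carbamoyl tells nothing.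

Compound 4, `O=C(CCCCCc1ccc(C(F)(F)F)cc1)N1CCOC1=O`, is the next step: trifluoromethyl in place of carbamoyl on an aromatic carbon. Going by the values given here, both groups that replaced hydroxy in compound 1 sat at the limit, and compound 1 remains the only measured compound with a number. Among the compounds with values here, none of the measured steps exchanges a group for trifluoromethyl, so the step from compound 3 to compound 4 has no direct precedent; the two large losses from compound 1 only mark where the carbamoyl stands.

The estimate for compound 4 is 4000 nM, with a range from 400 nM to 20000 nM. This estimate means a step of an at least 5.0-fold lower number from compound 3 to compound 4 (0.69 log units; beyond the scatter) from the limit of compound 3, expected with low confidence, since a limit gives no fixed starting point.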

Compound 4, half-maximal inhibitory concentration: 1040 nM
For compound 4 the middle estimate is 3.8-fold (0.59 log units) above the measured one; low and high end bracket the measured number.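

In this assay, every earlier replacement of hydroxy on this aromatic carbon had ended at a limit, not a number: the limit of > 20000 nM in this assay, at which 2 of the 4 values shown sit. Trifluoromethyl is the first replacement that gives a readable value, so this position accepts a group other than hydroxy, and the exchange reads as an at least 19-fold lower number from compound 3 to compound 4 (1.28 log units; beyond the scatter) and as an at least 19-fold lower number from compound 2 to compound 4 (1.28 log units; beyond the scatter). It does not reach the level of the hydroxy group, however, with a 17-fold higher number from compound 1 to compound 4 (1.23 log units; beyond the scatter), and among the four compounds shown hydroxy keeps the lowest number.

The compounds shown do not separate what trifluoromethyl itself contributes from the simple absence of the carbamoyl or carboxy group, a question that a hydrogen, a fluorine, a methoxy or a nitrile on this carbon would bear on. As far as these compounds go, how an amine on this carbon, or a longer chain on the core of compound 1, would stand in this assay also remains open.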